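This account rests on a few compounds, and the source may have more. Where it says the series, first, only, none or still open, it means among the compounds named here.

Two compounds of this series carry measurements. Compound 1 `COc1cc(/C=C/C(=O)C2=C(/C=C/c3ccc(O)c(OC)c3)NC(=O)NC2c2ccccc2)ccc1O` gives 10.5% in a functional assay, with a stated time of 20 min, tested at 2 uM; a lower number here means a weaker effect, a higher number a stronger effect of the compound at the concentration tested. Compound 2 `COc1cc(/C=C/C(=O)C2=C(/C=C/c3ccc(O)c(OC)c3)NC(=S)NC2c2ccccc2)ccc1O` gives 16.6% in this assay. Compound 2 stands alongside compound 1, the two values lying within the scatter of each other, so no separation between them is established. Compound 3 `COc1cc(/C=C/C(=O)C2=C(/C=C/c3ccc(O)c(OC)c3)NC(=S)NC2c2ccc(C)cc2)ccc1O` is not yet measured. Its difference from compound 2 is a single small one: methyl in place of hydrogen on an aromatic carbon. For the measured compounds named here, no measured pair shows such a change. In this assay the expected step is none beyond the scatter, a number 1.4 percentage points higher from compound 2 to compound 3 (within the scatter). Compound 3 is accordingly estimated at 18%, in a range from 7% to 32%.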

Compound 3, a percentage reported as activity, at one concentration (the size of the read-out at that concentration, not a potency): 10.2%
Beside the measured number, compound 3's estimate is 7.8 percentage points above it, and the stated range covers the measured number.
By their numbers in this assay, from the lowest: compounds 3, 1 and 2 (each within the scatter of the next).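

In this assay the first step read at this position, on the aromatic carbon para to a large group, is a number 6.4 percentage points lower from compound 2 to compound 3 (within the scatter) for phenyl to 4-methylphenyl. Methyl here therefore establishes no separation between the two compounds. Nothing on hand gives a reason for this result.

Going by these compounds, whether another group on this carbon, such as methoxy, chlorine or an amine, would give a step beyond the scatter stays open. So does whether methyl gives the same step on the core of compound 1.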